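Chain shortening on the amine-bearing core, sigma-2 binding

This account rests on a few compounds, and the source may have more. Where it says the series, first, only, none or still open, it means among the compounds named here.

Measured so far:
Compound 1 `OC1CC(NCCCCc2ccccc2)CCc2ccccc21`: 100 nM
Compound 2 `OC1Cc2ccccc2CCC1NCCCc1ccccc1`: 100 nM

Both figures come from an assay on membranes from liver for displacement of a labelled ligand from Sigma intracellular receptor 2 (Rattus norvegicus), read by scintillation counting, with a stated time of 120 min; on this read-out lower numbers stand for stronger inhibition and higher numbers for weaker inhibition. On that read-out compound 1 stands level with compound 2 at the digits shown; the two values sit within the scatter of each other, so no order can be drawn between them. Within the data shown here, no pair of measured compounds differs in a single place, so the series gives no measured step to lean on.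

Compound 3 `OC1CC(NCCCc2ccccc2)CCc2ccccc21` is the next member to be measured in this assay. Relative to compound 1 the change is phenyl in place of benzyl on a saturated chain carbon, three bonds along the chain from an amine nitrogen; in words, phenyl in place of benzyl on a saturated chain carbon, three bonds along the chain from an amine nitrogen. The core of compound 1 is kept; only the chain to the aromatic ring is affected.

Among the measured compounds shown here, with no measured step in hand, the expectation rests on the flat picture given by compound 1 and compound 2. The step of a 1.5-fold higher number from compound 1 to compound 3 (0.18 log units; within the scatter) is estimated to be small, if anything toward weaker binding, and probably not beyond the scatter. Compound 3 is therefore expected to give about 150 nM, with a range from 50 nM to 450 nM.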

Compound 3, inhibition constant: 28 nM
Estimate against measurement, compound 3: 5.4-fold (0.73 log units) above, and the stated range ends above it.
By their numbers in this assay, from the lowest: compound 3; then compounds 1 and 2 (each within the scatter of the next).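

In this assay, the chain gives the series its first measured step: phenyl in place of benzyl on a saturated chain carbon, three bonds along the chain from an amine nitrogen, gives a 3.6-fold lower number from compound 1 to compound 3 (0.55 log units; beyond the scatter), with the core of compound 1 kept. Binding at this receptor therefore responds to a change confined to this chain, something the level figures for compound 1 and compound 2 could not show, as that pair differs in more than one place. The data on hand offer nothing that accounts for this shift.

A single step fixes no trend with chain length, so the compounds shown leave open whether a still shorter chain would continue the move towards lower numbers or reverse it, and how a longer chain than that of compound 1 would read. Also open, from the compounds shown here alone, are whether the same change would carry over to the core of compound 2 and whether a methoxy group could stand in place of the hydroxyl on the core of compound 3 without altering the reading.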